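Adding a methylcyclopropyl group to the amide of a bicyclic amine

This account rests on a few compounds, and the source may have more. Where it says the series, first, only, none or still open, it means among the compounds named here.

Compounds measured so far:
- compound 1 `CCC(=O)N1CC2CC(C1)N2`: 5900 nM
- compound 2 `CCCC(=O)N1CC2CC(C1)N2`: 850 nM
- compound 3 `O=C(C1CCC1)N1CC2CC(C1)N2`: 11000 nM

All three share the same bicyclic amine core and differ only in the group on the carbonyl carbon of the amide. In an assay on SH-EP1 cells for agonist activity at Neuronal acetylcholine receptor; alpha4/beta2 (Homo sapiens), read by FLIPR and calcium flux (a higher number here means that more compound is needed for the effect, a lower number that less compound is needed), compound 1 gives 5900 nM, the second highest of the three numbers. Its nearest neighbour is compound 3, with a 1.9-fold higher number from compound 1 to compound 3 (0.27 log units; within the scatter). Compound 2 lies furthest away, with a 6.9-fold lower number from compound 1 to compound 2 (0.84 log units; beyond the scatter).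

The next compound, compound 4 `C[C@H]1C[C@H]1C(=O)N1CC2CC(C1)N2`, is not yet measured. It differs from compound 1 in one place: 2-methylcyclopropyl in place of ethyl on a carbonyl carbon

Among the compounds with values here, two measured steps bear on this. Going from ethyl to a small ring at the same place, a 1.9-fold higher number from compound 1 to compound 3 (0.27 log units; within the scatter), stayed within the scatter. Going from propyl to that ring, a 13-fold higher number from compound 2 to compound 3 (1.11 log units; beyond the scatter), was large. A methyl added two bonds from the carbonyl, a 6.9-fold lower number from compound 1 to compound 2 (0.84 log units; beyond the scatter), helped. The new group is between these cases, so no step beyond the scatter is expected, a 1.0-fold higher number from compound 1 to compound 4 (0.01 log units; within the scatter). Compound 4 is estimated at 6000 nM, with a range of 1500 nM to 24000 nM.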

Compound 4, half-maximal effective concentration: 5800 nM
For compound 4 the middle estimate is 1.0-fold (0.01 log units) above the measured one; low and high end bracket the measured number.
By their numbers in this assay, from the lowest: compound 2; then compounds 4, 1 and 3 (each within the scatter of the next).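

In this assay, the 2-methylcyclopropyl group, with 4 heavy atoms and a ring against 2 heavy atoms and no ring for ethyl, gives no step beyond the scatter (a 1.0-fold lower number from compound 1 to compound 4 (0.01 log units; within the scatter)). The same holds against cyclobutyl (a 1.9-fold lower number from compound 3 to compound 4 (0.28 log units; within the scatter)), so ethyl and both ring-bearing groups on this carbonyl carbon now give numbers that cannot be told apart, while the propyl group of compound 2 stands alone (a 6.8-fold higher number from compound 2 to compound 4 (0.83 log units; beyond the scatter)). No measurement available here explains why propyl differs from these three groups.

On these data alone, whether a longer chain, such as butyl, would lower the number further than propyl remains open. Also open, as far as these compounds go, are the mirror-image form of the 2-methylcyclopropyl group and the effect of an amine on the chain.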